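Aryl exchange at the saturated chain carbon of compound 2

A few compounds are considered here, and "the series" means these few. Any claim that something is new, unique, unknown or untested is made for them only; others in the source may bear on it.

Of the compounds shown here, two have been measured in an in vitro assay on CHOK cells for displacement of a labelled ligand from growth hormone secretagogue receptor type 1 (Homo sapiens); a higher number here means a weaker inhibitor, a lower number a stronger inhibitor. Compound 1 `CCc1nc(N)nc(N)c1-c1ccc(NCc2cc(F)c(S(=O)(=O)C(F)(F)F)c(F)c2)cc1` gives 21 nM. Compound 2 `CC(=O)c1ccc(CNc2ccc(-c3c(N)nc(N)nc3COCc3ccccc3)cc2)cc1` gives 1.2 nM, the lowest of the two numbers; the gap from compound 1 to compound 2 is beyond the scatter, but these two differ in more than one place, so no single-change step can be read from them. Compound 3 `Nc1nc(N)c(-c2ccc(NCc3cnc4ccccc4c3)cc2)c(COCc2ccccc2)n1` is not yet measured and differs from compound 2 in one place: quinolin-3-yl in place of 4-acetylphenyl on a saturated chain carbon bound to a nitrogen on an aromatic ring. Within the data shown here, no measured pair shows this change, so its effect is unknown from the series itself. The expected step is a 2.5-fold higher number from compound 2 to compound 3 (0.40 log units; beyond the scatter), a weakening judged somewhat more likely than a strengthening, though not clearly beyond the scatter. Compound 3 is therefore estimated at 3 nM in this assay, within a range from 0.8 nM to 12 nM.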

Compound 3, half-maximal inhibitory concentration: 130 nM
The estimate for compound 3 lay 43-fold (1.64 log units) below the measured number; the whole stated range lies below it.
By their numbers in this assay, from the lowest: compound 2; then compound 1; then compound 3.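

In this assay, among these compounds, the place on a saturated chain carbon bound to a nitrogen on an aromatic ring proves highly sensitive to the aryl group it carries: quinolin-3-yl in place of 4-acetylphenyl gives a 110-fold higher number from compound 2 to compound 3 (2.03 log units; beyond the scatter) and provides the first single-change reading. Both groups have no hydrogen-bond donors and one hydrogen-bond acceptor, so those counts do not distinguish the two groups despite the large step. Nothing measured here accounts for the size of this step.

Going by these compounds, it remains open whether the loss follows from the departure of the acetyl group or from the arrival of quinolin-3-yl; a plain phenyl and a naphthalen-2-yl at this place would separate the two. Also open, on these data alone, is whether the same exchange has a similar effect on the core of compound 1.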